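A few compounds are considered here, and "the series" means these few. Any claim that something is new, unique, unknown or untested is made for them only; others in the source may bear on it.

Measured so far in a functional assay on Jurkat cells for inhibition of nuclear factor NF-kappa-B complex (Homo sapiens); on this read-out lower numbers stand for stronger inhibition and higher numbers for weaker inhibition:
- compound 1 `CCOC(=O)c1cnc(-c2ccncc2)nc1NN1C(=O)C=C(C)C1=O`: 6000 nM
- compound 2 `CCOC(=O)c1cnc(-c2cnc3ccccc3c2)nc1NN1C(=O)C=C(C)C1=O`: 6000 nM
- compound 3 `CCOC(=O)c1cnc(-c2ccc(C(F)(F)F)cc2)nc1NN1C(=O)C=C(C)C1=O`: 400 nM

Compound 1 sits level with compound 2; together the two give the highest numbers of the three, and compound 3 stands apart from both with a clearly lower number. The two steps that depart from compound 1 read differently: no change at the digits printed from compound 1 to compound 2 (within the scatter), whereas a 15-fold lower number from compound 1 to compound 3 (1.18 log units; beyond the scatter), and likewise a 15-fold lower number from compound 2 to compound 3 (1.18 log units; beyond the scatter).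

Compound 4 `CCOC(=O)c1cnc(S(=O)(=O)c2ccccc2)nc1NN1C(=O)C=C(C)C1=O` is the next member. It differs from compound 1 by phenylsulfonyl in place of pyridin-4-yl on an aromatic carbon. For the measured compounds named here, no measured step exchanges the group for one joined through a sulfonyl, so the bearing steps are indirect: the step from compound 1 to compound 3 shows that leaving the ring nitrogen out of the group at this carbon can bring a large drop in the number, while the step from compound 1 to compound 2 shows a heteroaryl exchange that changes nothing. Phenylsulfonyl brings a ring of carbon only, as in compound 3, but through a different link, so a moderate move toward compound 3 is expected rather than a full one, and the estimate is a 2.0-fold lower number from compound 1 to compound 4 (0.30 log units; within the scatter). For compound 4 the expected value is 3000 nM, with a range from 600 nM to 15000 nM.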

Compound 4, half-maximal inhibitory concentration: 10000 nM
Compound 4: middle estimate off by 3.3-fold (0.52 log units), on the low side; low and high end bracket the measured number.
By their numbers in this assay, from the lowest: compound 3; then compounds 1, 2 and 4 (each within the scatter of the next).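

In this assay, a carbon-only ring at the carbon between two ring nitrogen atoms does not by itself bring the low number of compound 3: the phenylsulfonyl group gives a 25-fold higher number from compound 3 to compound 4 (1.40 log units; beyond the scatter). Compound 4 instead reads with the two heteroaryl compounds, with a 1.7-fold higher number from compound 1 to compound 4 (0.22 log units; within the scatter) and a 1.7-fold higher number from compound 2 to compound 4 (0.22 log units; within the scatter), so among these four compounds only compound 3 stands apart. Nothing at hand explains the gap between phenylsulfonyl and 4-(trifluoromethyl)phenyl.

Phenylsulfonyl and 4-(trifluoromethyl)phenyl differ in both the sulfonyl link and the trifluoromethyl group, and a plain phenyl joined directly to this carbon would separate the two. On these data alone, how an amine such as morpholine or a 4-chlorophenyl group would read at this carbon also remains open.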